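The compounds below may be only part of what the source reports. "The series", "measured", "known", "first", "only" and "open" are said of these compounds alone.

The series is followed in an ADME assay on microsomes from liver (Mus musculus) for metabolic stability, read by LC-MS, using NADPH, with stated times of 10 min and 30 min; on this read-out lower numbers stand for slow clearance and higher numbers for fast clearance. Compound 1 `CC[C@@H]1c2cc(Cl)ccc2C(=O)N1c1cncc2c1CCC[C@H]2NC(C)=O` reports only a limit in this assay, namely < 20.2 mL/min/kg. Compound 2 `CCC1c2cc(Cl)ccc2C(=O)N1c1cccnc1` gives 65.9 mL/min/kg in this assay, and compound 3 `CC1c2cc(Cl)ccc2C(=O)N1c1cccnc1` gives 66.5 mL/min/kg. The difference between the core of compound 1 and the core of compound 2 is not broken down here. Between compound 2 and compound 3 the change is hydrogen in place of methyl on a saturated chain carbon bound to a saturated ring carbon, and the measured step is a 1.0-fold higher number from compound 2 to compound 3 (0.00 log units; within the scatter). Compound 4 `CC(=O)N[C@@H]1CCCc2c1cncc2N1C(=O)c2ccc(Cl)cc2[C@H]1C` has not yet been measured in this assay. It differs from compound 1 by hydrogen in place of methyl on a saturated chain carbon bound to a saturated ring carbon, the same change as that made from compound 2 to compound 3, at the same place. The expectation for compound 4 rests on two points: compound 1 sits at the limit of < 20.2 mL/min/kg in this assay, at which 1 of the 3 values shown sits, and the same change gave a 1.0-fold higher number from compound 2 to compound 3 (0.00 log units; within the scatter), a step within the scatter. On that basis the expected step is a step that the limit leaves unreadable from compound 1 to compound 4. Compound 4 is therefore expected to show 15 mL/min/kg in this assay, with the estimate running from 7 mL/min/kg to 32 mL/min/kg.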

Compound 4, clearance: 43.5 mL/min/kg
Compound 4: the middle estimate sits 2.9-fold (0.46 log units) below what was measured, and the stated range ends below it.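

In this assay the change from ethyl to methyl on the core of compound 1 gives an at least 2.1-fold higher number from compound 1 to compound 4 (0.33 log units; beyond the scatter), so on this core the step lies beyond the scatter, while the same change on the core of compound 2 gave a 1.0-fold higher number from compound 2 to compound 3 (0.00 log units; within the scatter). For compound 1 the entry < 20.2 mL/min/kg is a limit and not a number. The result therefore does not establish that the core alters the effect of this change, and two pairs give no rule for the series: the same change on two cores in this assay, a 1.0-fold higher number (0.00 log units; within the scatter) from compound 2 to compound 3 and an at least 2.1-fold higher number (0.33 log units; beyond the scatter) from compound 1 to compound 4; the limit leaves it open whether they differ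

The compounds shown compare only ethyl and methyl at this place, so the effect of a longer chain such as propyl, or of a chain ending in an amine, stays open in this assay. Also open is which part of the difference between the core of compound 1 and the core of compound 2 separates the values of the two pairs, since no pair shown changes the core in one place.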